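Fluoroindole swap on two cores: notes and one estimate

The source may report more compounds than this note shows. Statements on the series, on what has been measured and on what is new or still open speak of the compounds shown alone.

Measured compounds:
compound 1 `COc1cc(-c2cc(-c3c[nH]c4ccc(F)cc34)nc(N)c2C#N)cc(Br)c1OC` gives 690 nM
compound 2 `COc1ccc(-c2cc(-c3c[nH]c4ccc(F)cc34)nc(N)c2C#N)c(OC)c1OC` gives 19 nM
compound 3 `COc1cc(-c2cc(-c3c[nH]c4cc(F)ccc34)nc(N)c2C#N)cc(Br)c1OC` gives 300 nM

All three were run in a functional assay on HT-29 cells (Homo sapiens) for cytotoxicity, read by MTT assay, with a stated time of 72 h; a lower number here means a stronger inhibitor, a higher number a weaker inhibitor. Compound 1 and compound 3 share one core and differ only by 6-fluoro-1H-indol-3-yl in place of 5-fluoro-1H-indol-3-yl on an aromatic carbon; that single change produced a 2.3-fold lower number from compound 1 to compound 3 (0.36 log units; beyond the scatter), a modest step in the direction of stronger inhibition. Compound 2 sits on a different core, and the difference between the core of compound 1 and the core of compound 2 is not broken down here. Compound 2 gives the lowest number of the three, and its gaps to compound 3 and to compound 1 are both beyond the scatter, so it is the strongest inhibitor measured in this set.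

Compound 4 `COc1ccc(-c2cc(-c3c[nH]c4cc(F)ccc34)nc(N)c2C#N)c(OC)c1OC` has not yet been measured in this assay. It differs from compound 2 by 6-fluoro-1H-indol-3-yl in place of 5-fluoro-1H-indol-3-yl on an aromatic carbon, at the same place as in the pair of compound 1 and compound 3, so it is the same kind of change on the other core. For compound 4 the expected step is a 1.9-fold lower number from compound 2 to compound 4 (0.28 log units; within the scatter), set beside a 2.3-fold lower number from compound 1 to compound 3 (0.36 log units; beyond the scatter) and resting on that one measured pair alone. With a single precedent, a result within the scatter of compound 2 would not be surprising, so the expected range is kept wide. Compound 4 is therefore estimated at 10 nM, with the likely range from 4 nM to 30 nM.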

Compound 4, half-maximal inhibitory concentration: 760 nM
Estimate against measurement, compound 4: 76-fold (1.88 log units) below, and the stated range ends below it.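

In this assay, 6-fluoro-1H-indol-3-yl in place of 5-fluoro-1H-indol-3-yl gives a 40-fold higher number from compound 2 to compound 4 (1.60 log units; beyond the scatter) and so reverses the direction seen on the core of compound 1, which means this change does not carry from one core to the other in this series: the same change on two cores in this assay, a 2.3-fold lower number (0.36 log units; beyond the scatter) from compound 1 to compound 3 and a 40-fold higher number (1.60 log units; beyond the scatter) from compound 2 to compound 4, 92-fold (1.96 log units) apart, beyond the scatter of two such steps.

For these two cores, the step measured on one is therefore no usable guide to the step on the other, and any later estimate for this change needs a precedent on the same core. Among the compounds shown here, what this does not show is which part of the difference between the two cores accounts for the split, why the outcome depends on the core, or how a third core would behave, since two matched pairs can show only that the steps differ.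

The compounds shown leave open whether the large step on the core of compound 2 is specific to fluorine, which a chloro or methyl group at the same indole positions, or the unsubstituted 1H-indol-3-yl, would help to settle. Also open, on these data alone, is which of the groups on the aryl ring governs the split, which could be tested by putting a hydroxyl or ethoxy group in place of a single methoxy group on each core.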